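The source may report more compounds than this note shows. Statements on the series, on what has been measured and on what is new or still open speak of the compounds shown alone.

Measured compounds:
- compound 1 `C#Cc1cccc(Nc2ncnc3oc(C)c(C(=O)OCC)c23)c1` gives > 1000000 nM (a limit)
- compound 2 `CCOC(=O)c1c(C)oc2ncnc(Nc3ccc(OCc4cccc(F)c4)c(Cl)c3)c12` gives 500 nM as a number
- compound 3 `CCOC(=O)c1c(C)oc2ncnc(Nc3ccccc3)c12` gives > 1000000 nM (a limit)

In a functional assay on A549 cells (Homo sapiens) for cytotoxicity, read by MTT assay, with a stated time of 72 h (on this read-out lower numbers stand for stronger inhibition and higher numbers for weaker inhibition), compound 3 gives > 1000000 nM as a limit of the assay and not a number. Its standing is set by the limit of > 1000000 nM in this assay, at which 2 of the 3 values shown sit, and gives no number to step from.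

Compound 4 `CCOC(=O)c1c(C)oc2ncnc(Nc3cccc(Cl)c3)c12` follows from compound 3 by chloro in place of hydrogen on an aromatic carbon, meta to a large group: chloro in place of hydrogen on an aromatic carbon is the whole change.

Going by the values given here, the only measured step, a step that the two limits leave unreadable from compound 1 to compound 3, also swaps hydrogen with a substituent on an aromatic carbon, and it stays unreadable. Compound 2 alone gives a number, 500 nM as its value, but it differs from compound 3 in more than one place and sets no size for a single chloro.

In this assay only a modest move toward stronger inhibition is therefore expected, with a result at the limit quite likely. The estimated step is an at least 1.4-fold lower number from compound 3 to compound 4 (0.15 log units; that floor lies within the scatter) as expected here. For compound 4 the estimated value is 700000 nM with an expected range from 100000 nM to 1500000 nM as its spread.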

Compound 4, half-maximal inhibitory concentration: > 1000000 nM
Compound 4: a limit, no number (the forecaster's own chance of this, stated with the estimate: 60%); middle value at least 1.4-fold (0.15 log units) from the limit.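

In this assay compound 4 gives > 1000000 nM, which is a limit of the assay and not a number. The steps from compound 3 and from compound 1 to compound 4 cannot be read, so chloro on the phenyl ring adds no measurable size to the series: the limit of > 1000000 nM in this assay, at which 3 of the 4 values shown sit. Going by these compounds alone, the one readable step is an at least 2000-fold higher number from compound 2 to compound 4 (3.30 log units; beyond the scatter) with hydrogen in place of (3-fluorobenzyl)oxy, which shows that a chloro is present both with a number and at the limit, and that in this pair the difference goes with the (3-fluorobenzyl)oxy group.

On these data alone, whether that group gives a number without the chloro remains open. Also open, as far as these compounds go, is whether a smaller ether such as methoxy, or an amine, at that place would bring a value off the limit.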